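Triazole-bearing tetracyclic series: cytotoxicity ahead of compound 4

The source may report more compounds than this note shows. Statements on the series, on what has been measured and on what is new or still open speak of the compounds shown alone.

Measured compounds:
compound 1 `C=C1C[C@]23C[C@@]1(O)CC[C@H]2c1ccc(OS(=O)(=O)c2ccc(C)cc2)c(C)c1[C@@H]3Cn1cc(-c2ccc(OC)cc2)nn1` — > 20000 nM
compound 2 `COc1ccc(-c2cn(C[C@H]3c4c(ccc(O)c4C)[C@@H]4CC[C@@]5(C)C[C@]43CC5=O)nn2)cc1` — > 20000 nM
compound 3 `C=C1C[C@]23C[C@@]1(O)CC[C@@H]2c1cccc(C)c1[C@@H]3Cn1cc(-c2ccc(Br)cc2)nn1` — > 20000 nM

All three values come from a functional assay on SMMC-7721 cells (Homo sapiens) for cytotoxicity, read by MTT assay, with a stated time of 4 days; a lower number here means a stronger inhibitor, a higher number a weaker inhibitor. Each of them is a limit of the assay, not a number. Compound 2 sits at the limit with > 20000 nM. Compound 1 likewise reports only a limit, > 20000 nM. Compound 3 also gives a limit, > 20000 nM. So compound 2 stands nowhere apart from its neighbours: the whole measured set rests on (the limit of > 20000 nM in this assay, at which 3 of the 3 values shown sit), and no ordering among the three can be read from it.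

The next compound in this assay is compound 4 `Cc1c(O)ccc2c1[C@H](Cn1cc(-c3ccc(F)cc3)nn1)[C@@]13CC(=O)[C@@](C)(CC[C@@H]21)C3`. Against compound 2 the change is fluoro in place of methoxy on an aromatic carbon; it is a small swap on the outer aryl of the triazole, the shared core untouched.

For the measured compounds named here, with no measured step to lean on, and compound 2 at > 20000 nM, the expectation for this assay is no movement beyond the scatter, in either direction. The step from compound 2 to compound 4 is expected to read a step that the limit leaves unreadable from compound 2 to compound 4. Compound 4 is estimated at 30000 nM, in the range 10000 nM to 100000 nM, most probably reported again only as a limit.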

Compound 4, half-maximal inhibitory concentration: > 20000 nM
Compound 4: only a limit was reported; the forecaster's own chance of this, stated with the estimate: 85%; the middle value does not contradict the limit.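

Compound 4 reports only a limit, > 20000 nM. Compound 2 is also a limit, so the change from 4-methoxyphenyl to 4-fluorophenyl gives no readable step between compound 2 and compound 4. The compounds shown leave open whether any change on this series gives a measurable value, and how these four would order: the limit of > 20000 nM in this assay, at which 4 of the 4 values shown sit.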